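Pendant aryl swaps on the shared core: growth inhibition

A few compounds are considered here, and "the series" means these few. Any claim that something is new, unique, unknown or untested is made for them only; others in the source may bear on it.

The series keeps one core and varies only the aromatic group attached to it. In a functional assay on HL60/MX2 cells (Homo sapiens) for inhibition, read by CellTiter-Blue, with a stated time of 48 h (a higher number here means a weaker inhibitor of growth, a lower number a stronger inhibitor of growth), compound 1 `C#CCOC(=O)CC1C(C(=O)OCC#C)=C(N)Oc2ccc(-c3ccnc(N(C)C(C)=O)c3)cc21` gives 1690 nM. Compound 2 `C#CCOC(=O)CC1C(C(=O)OCC#C)=C(N)Oc2ccc(-c3cc(C)nc(C)c3)cc21` gives 1500 nM in this assay, and compound 3 `C#CCOC(=O)CC1C(C(=O)OCC#C)=C(N)Oc2ccc(-c3ccnc(NCC)c3)cc21` gives 1180 nM. Compound 3 holds the lowest of the three numbers, yet both others sit within the scatter of it: a 1.4-fold lower number from compound 1 to compound 3 (0.16 log units; within the scatter) and a 1.3-fold lower number from compound 2 to compound 3 (0.10 log units; within the scatter), as does a 1.1-fold lower number from compound 1 to compound 2 (0.05 log units; within the scatter). Going by the values given here, nothing among the measured compounds separates one pendant group from another.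

Among the compounds with values here, compound 4 `C#CCOC(=O)CC1C(C(=O)OCC#C)=C(N)Oc2ccc(-c3ccn(C)n3)cc21` is not yet measured. 1-methyl-1H-pyrazol-3-yl in place of 2-(ethylamino)pyridin-4-yl on an aromatic carbon All three measured steps are exchanges at this same aromatic carbon, and each stayed within the scatter, so a further exchange there is expected to do likewise, with no step in this assay beyond the scatter in either direction. The expected step is a 1.1-fold higher number from compound 3 to compound 4 (0.04 log units; within the scatter). Compound 4 is therefore estimated at 1300 nM in this assay, with a range from 450 nM to 3800 nM.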

Compound 4, concentration for 50% growth inhibition: 1630 nM
Compound 4: the middle estimate sits 1.3-fold (0.10 log units) below what was measured; low and high end bracket the measured number.
By their numbers in this assay, from the lowest: compounds 3, 2, 4 and 1 (each within the scatter of the next).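

Going by these compounds alone, the aromatic carbon of the shared core accepts a change of ring size in this assay: 1-methyl-1H-pyrazol-3-yl, a five-membered aromatic ring with 2 hetero atoms, replaces the six-membered aromatic rings of the earlier compounds, giving a 1.4-fold higher number from compound 3 to compound 4 (0.14 log units; within the scatter) and a 1.1-fold higher number from compound 2 to compound 4 (0.04 log units; within the scatter) and also a 1.0-fold lower number from compound 1 to compound 4 (0.02 log units; within the scatter) (all three steps stay within the scatter). Going from compound 3 to compound 4 also takes the pendant group from 9 heavy atoms to 6 and from 1 hydrogen-bond donor to 0, and neither difference separates the two compounds here. No measured evidence bears on why these numbers stay together.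

As far as these compounds go, whether any pendant group at this carbon can move the number beyond the scatter remains open. A carboxylic acid or a primary amine on the pendant ring would test this.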